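The source may hold more compounds than are shown below. What is called first, only, known or untested is meant among the compounds shown, and "the series" means these compounds.

Within the data shown here, the three compounds measured so far share one core and differ only in the alkyl group of the ester. Compound 1 `CC(C)COC(=O)C(O)Cn1cnc2c(N)ncnc21` carries an isobutyl ester, compound 2 `CC(C)CCOC(=O)C(O)Cn1cnc2c(N)ncnc21` an isopentyl ester and compound 3 `CCOC(=O)C(O)Cn1cnc2c(N)ncnc21` an ethyl ester. In a functional assay on Vero cells (Chlorocebus sabaeus) for cytotoxicity (a lower number here means that less compound is tolerated, a higher number that more compound is tolerated), compound 1 reaches only the limit of the assay, > 400 ug/mL. In this assay compound 2 gives 400 ug/mL. Compound 3 in this assay likewise stops at the limit of the assay, > 400 ug/mL. Compound 3 thus sits where tolerance is at least as high as any value shown, and the steps among the three are hard to read: a number no higher from compound 1 to compound 2 (the limit leaves the size open), a step that the two limits leave unreadable from compound 1 to compound 3 and a number no lower from compound 2 to compound 3 (the limit leaves the size open), all because of the limit of > 400 ug/mL in this assay, at which 2 of the 3 values shown sit.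

Compound 4 `COC(=O)C(O)Cn1cnc2c(N)ncnc21` is the next member of this ester series, and its change from compound 3 is hydrogen in place of methyl on a saturated chain carbon bound to an oxygen next to a carbonyl group. The measured steps that bear on it are the ester changes just named, and none of them shows a readable change in tolerance, so no step beyond the scatter is expected in this assay. Compound 4 is therefore expected to give about 400 ug/mL in this assay, between 200 ug/mL and 800 ug/mL. The step from compound 3 is estimated as a number no higher from compound 3 to compound 4 (the limit leaves the size open).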

Compound 4, minimum cytotoxic concentration: > 400 ug/mL
Compound 4 was reported as a limit (the forecaster's own chance of this, stated with the estimate: 75%); the middle value sits exactly at the limit.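

In this assay compound 4 gives > 400 ug/mL, and this is a limit of the assay. The change from ethoxycarbonyl to methoxycarbonyl therefore adds a fourth ester to the series with no readable change in tolerance, and the shortest ester shown reaches the same limit as the ethyl and isobutyl esters. Only a number no lower from compound 2 to compound 4 (the limit leaves the size open) has a direction, the other new steps cannot be read, and none of the new steps has a readable size because of this limit: the limit of > 400 ug/mL in this assay, at which 3 of the 4 values shown sit.

The compounds shown leave open how far the true values of compound 1, compound 3 and compound 4 lie beyond the limit in this assay, and whether a longer chain than the isopentyl ester of compound 2 would lower the tolerated concentration further. They also leave open what a carboxylic acid or an amide in place of the ester would do to the tolerated concentration on the shared core.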